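This account rests on a few compounds, and the source may have more. Where it says the series, first, only, none or still open, it means among the compounds named here.

Measured compounds in a physicochemical assay for solubility, read by HPLC, with a stated time of 24 h; on this read-out lower numbers stand for lower solubility and higher numbers for higher solubility:
Compound 1, `CCN1CCN(C[C@H]2CN(c3ccc(-n4cc(-c5ccccn5)cn4)c(F)c3)C(=O)O2)CC1`, gives 706000 nM.
Compound 2, `O=C1O[C@@H](Cn2ccnn2)CN1c1ccc(-n2cc(-c3ccccn3)cn2)c(F)c1`, gives 247000 nM.
Compound 3, `CS(=O)(=O)NC[C@H]1CN(c2ccc(-n3cc(-c4ccccn4)cn3)c(F)c2)C(=O)O1`, gives 2300 nM.

Compound 3 stands lowest of the three in this assay. Both steps that lead to it are large: a 310-fold lower number from compound 1 to compound 3 (2.49 log units; beyond the scatter) and a 110-fold lower number from compound 2 to compound 3 (2.03 log units; beyond the scatter), whereas the step between the two higher compounds, a 2.9-fold lower number from compound 1 to compound 2 (0.46 log units; beyond the scatter), is modest. Compound 4, `CONC(=O)[C@H]1CN(c2ccc(-n3cc(-c4ccccn4)cn3)c(F)c2)C(=O)O1`, has not yet been measured. It differs from compound 3 as follows: methoxycarbamoyl in place of (methanesulfonamido)methyl on a saturated ring carbon. For the measured compounds named here, no measured compound carries a methoxycarbamoyl group, and no measured step exchanges methanesulfonamido for it, so none of the three steps bears directly on this change. The two large steps into compound 3 show only how far the methanesulfonamido compound lies beneath the others; they do not tell whether the incoming group returns any of that ground. Compound 4 is therefore expected to lie near compound 3, with a step estimated as a 2.2-fold higher number from compound 3 to compound 4 (0.34 log units; beyond the scatter), small and uncertain in direction. Compound 4 is estimated at 5000 nM, with a range from 1000 nM to 30000 nM.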

Compound 4, solubility: 78100 nM
Compound 4: the middle estimate sits 16-fold (1.19 log units) below what was measured; measured number outside the range, above it.
By their numbers in this assay, from the lowest: compound 3; then compound 4; then compound 2; then compound 1.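

In this assay, the saturated ring carbon next to the ring oxygen proves sensitive to this exchange: a 34-fold higher number from compound 3 to compound 4 (1.53 log units; beyond the scatter) is a large step, even though the leaving and entering groups have the same hydrogen-bond donor and acceptor counts and no net charge. The low number of compound 3 is therefore not shared by every group with these counts at this position, and the remaining steps are modest: a 3.2-fold lower number from compound 2 to compound 4 (0.50 log units; beyond the scatter) and a 9.0-fold lower number from compound 1 to compound 4 (0.96 log units; beyond the scatter). Nothing measured here explains these differences.

The exchange alters both the group and its attachment, so the compounds leave open whether the sulfonamide or the methyl link accounts for the step. An acetamidomethyl group or a simple carboxylic acid on the same ring carbon would be the next groups to compare.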